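A few compounds are considered here, and "the series" means these few. Any claim that something is new, unique, unknown or untested is made for them only; others in the source may bear on it.

Three compounds of the series have numbers in an in vitro assay on HEK385-7 cells for displacement of a labelled ligand from prostaglandin D2 receptor 2 (Homo sapiens); a lower number here means a stronger inhibitor, a higher number a weaker inhibitor. Compound 1 `CCC(c1ccccc1)c1nc(-c2ccc(Cl)cc2)c(CC(=O)O)s1` gives 190 nM. Compound 2 `COc1cc(-c2nc(C(c3ccc(F)cc3)c3ccc(F)cc3)sc2CC(=O)O)ccn1` gives 29 nM. Compound 3 `O=C(O)Cc1sc(C(c2ccccc2)c2ccccc2)nc1-c1ccc(F)c(F)c1` gives 4.1 nM. Compound 2 thus stands second highest of the three numbers: compound 1 sits a step above it that is beyond the scatter, and compound 3 sits a step below it that is also beyond the scatter. No two of these three compounds differ in one place only, so none of the gaps between them can be tied to a single change; compounds 1 and 3 each differ from compound 2 in several places at once.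

Compound 4 `Cc1cc(-c2nc(C(c3ccc(F)cc3)c3ccc(F)cc3)sc2CC(=O)O)ccn1` is not yet measured. It differs from compound 2 in one place: methyl in place of methoxy on an aromatic carbon. For the measured compounds named here, no measured pair carries this change, so its effect in this assay cannot be read from the data. The working expectation is a step of no more than the usual scatter, in either direction, and the estimate below corresponds to a 1.2-fold higher number from compound 2 to compound 4 (0.08 log units; within the scatter). Compound 4 is expected to give 35 nM, within a range from 12 nM to 100 nM.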

Compound 4, half-maximal inhibitory concentration: 3.1 nM
Compound 4: the middle estimate sits 11-fold (1.05 log units) above what was measured; the measured number lies below the stated range.
By their numbers in this assay, from the lowest: compounds 4 and 3 (each within the scatter of the next); then compound 2; then compound 1.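

In this assay, for the compounds shown here, going from 2-methoxypyridin-4-yl to 2-methylpyridin-4-yl gives a 9.4-fold lower number from compound 2 to compound 4 (0.97 log units; beyond the scatter) and is the first gap that can be tied to a single change. The position next to the ring nitrogen is therefore not indifferent to what it carries, at least in this pair, where methoxy leaves with one hydrogen-bond acceptor and methyl enters with none, though one pair cannot separate that difference from the change in heavy atoms. No measurement at hand bears on why the number moves.

From the compounds shown here alone, the change appears in one pair only, so whether it holds with other groups elsewhere on the core remains open. Also open, going by these compounds, is how the same position responds to hydrogen, ethyl, chlorine or an amine, and thus whether the step follows from the presence of methyl or from the loss of the methoxy oxygen.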